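A few compounds are considered here, and "the series" means these few. Any claim that something is new, unique, unknown or untested is made for them only; others in the source may bear on it.

Compound 1 `CCc1nc(N)c2nn(-c3ccccc3)cc2n1` and compound 2 `COc1ccc(Cc2nc(N)c3nn(-c4ccccc4)cc3n2)cc1` share one core and differ only on a saturated chain carbon bound to an aromatic carbon. In an assay on CHO cells for displacement of a labelled ligand from adenosine receptor A3 (Homo sapiens), read by scintillation counting, tested at 1 uM (a higher number here means more inhibition at the concentration tested (going by the name of the read-out), a lower number less inhibition), compound 1 gives 38%, and compound 2 gives 38%; the step of no change at the digits printed from compound 1 to compound 2 (within the scatter), so compound 2 stands level with compound 1 at the digits shown, with nothing yet separating the two. Compound 3 `Nc1nc(Cc2ccccc2Cl)nc2cn(-c3ccccc3)nc12` is not yet measured. (2-chlorophenyl in place of 4-methoxyphenyl on a saturated chain carbon bound to an aromatic carbon). Among the measured compounds shown here, the only measured step that bears on this place is the one from compound 1 to compound 2, and it was flat, so exchanging one six-membered aromatic ring of carbon only for another at the same place is expected to move little, with no step beyond the scatter anticipated. This step is expected as no change at the digits printed from compound 2 to compound 3 (within the scatter). Compound 3 is estimated at 38% in this assay, with a range from 22% to 55%.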

Compound 3, a percentage reported as inhibition, at one concentration (the size of the read-out at that concentration, not a potency): 22%
The estimate for compound 3 lay 16 percentage points above the measured number; low and high end bracket the measured number.
By their numbers in this assay, from the lowest: compound 3; then compounds 1 and 2 (each within the scatter of the next).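

In this assay, this position is no longer flat: with 2-chlorophenyl in place of 4-methoxyphenyl on the saturated chain carbon, the step is a number 16 percentage points lower from compound 2 to compound 3 (beyond the scatter). With 2-chlorophenyl in place of methyl, the step is a number 16 percentage points lower from compound 1 to compound 3 (beyond the scatter), so the two aryl groups, each one six-membered aromatic ring of carbon only, do not behave alike at this place, and the presence of such a ring alone does not set the read-out. Nothing available explains this difference.

The 4-methoxyphenyl and 2-chlorophenyl groups differ in both substituent and its location on the ring, so the contribution of each remains unresolved. On these data alone, how a plain phenyl or a saturated cyclohexyl ring would read at this place also remains open.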